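Aminopyrazolopyrimidine series: paw edema inhibition notes

The source may report more compounds than this note shows. Statements on the series, on what has been measured and on what is new or still open speak of the compounds shown alone.

Measured so far:
compound 1 `Nc1cc(-c2ccc(Cl)cc2)nc2cc(-c3ccccc3)nn12` gives 13.8%
compound 2 `Cc1ccc(-c2cc(N)n3nc(-c4ccccc4)cc3n2)cc1` gives 37.5%
compound 3 `Nc1cc(-c2ccc(Cl)cc2)nc2cc(-c3ccc(Br)cc3)nn12` gives 72.5%

All three were read in a functional assay on the whole organism (strain Wistar) for inhibition, with Rattus norvegicus as the target, read by paw edema, with stated times of 30 min and 2 h, at a dose of 50 mg/kg by the oral route; a lower number here means less inhibition, a higher number more inhibition at the dose given (going by the name of the read-out). Compound 1 is the lowest of the three. Compound 2 differs from compound 1 by methyl in place of chloro on an aromatic carbon and this change made a step of a number 23.7 percentage points higher from compound 1 to compound 2 (beyond the scatter). Compound 3 differs from compound 1 by bromo in place of hydrogen on an aromatic carbon and this change made a step of a number 58.7 percentage points higher from compound 1 to compound 3 (beyond the scatter). Compound 3 is the highest of the three, beyond the scatter against both others, and compound 2 is the nearest to it.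

Compound 4 `Cc1ccc(-c2cc(N)n3nc(-c4ccc(Br)cc4)cc3n2)cc1` is not yet measured. It differs from compound 3 by methyl in place of chloro on an aromatic carbon, which is the same change as that from compound 1 to compound 2, made twice within the set; the two cores differ by bromo in place of hydrogen on an aromatic carbon. An upward step is expected for compound 4 in this assay, estimated at a number 10.5 percentage points higher from compound 3 to compound 4 (beyond the scatter), smaller than the earlier a number 23.7 percentage points higher from compound 1 to compound 2 (beyond the scatter) because compound 3 already stands at 72.5%. Compound 4 is therefore estimated at 83%, with a range from 66% to 96%.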

Compound 4, a percentage reported as inhibition, in the whole organism at one dose (the size of the read-out at that dose, not a potency): 76.3%
Estimate against measurement, compound 4: 6.7 percentage points above; the measured number falls inside the stated range.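

In this assay, methyl in place of chloro on the 4-chlorophenyl group does not carry over in size to the core of compound 3, where the change gives a number 3.8 percentage points higher from compound 3 to compound 4 (within the scatter): the same change on two cores in this assay, a number 23.7 percentage points higher (beyond the scatter) from compound 1 to compound 2 and a number 3.8 percentage points higher (within the scatter) from compound 3 to compound 4, 19.9 percentage points apart, beyond the scatter of two such steps Bromo in place of hydrogen keeps its upward direction on both cores but not its size, giving a number 38.8 percentage points higher from compound 2 to compound 4 (beyond the scatter): the same change on two cores in this assay, a number 58.7 percentage points higher (beyond the scatter) from compound 1 to compound 3 and a number 38.8 percentage points higher (beyond the scatter) from compound 2 to compound 4, 19.9 percentage points apart, beyond the scatter of two such steps The four compounds thus show that the size of each step depends on the group present at the other place, so neither step can be transferred unchanged within this set, but they do not show the reason for this, and a read-out at one dose says nothing about potency.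

Left open is whether the same dependence appears with other groups in place of the chloro, such as methoxy or an amine, or in place of the bromo, such as fluoro or a carboxylic acid. Also open, from the compounds shown here alone, is whether it holds on any core beyond these two pairs.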